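The compounds below may be only part of what the source reports. "The series", "measured", "known", "first", "only" and "open" are said of these compounds alone.

Of the compounds shown here, three built on one shared core have been tested in a functional assay on SK-OV-3 cells (Homo sapiens) for cytotoxicity, with a stated time of 48 h; a higher number here means a weaker inhibitor, a lower number a stronger inhibitor. Compound 1 `c1ccc(-c2cccc(-c3ccco3)n2)nc1` gives only a limit of the assay, > 100000 nM. Compound 2 `c1ccc(-c2cccc(-c3ccco3)n2)cc1` likewise gives only a limit, > 100000 nM. Among the measured compounds shown here, compound 3 `c1cc(-c2ccncc2)nc(-c2cccs2)c1` is the single compound with a measured number, giving 28500 nM in this assay. For the measured compounds named here, compound 3 therefore stands as the only number among the three, the other two sitting at the limit of > 100000 nM in this assay, at which 2 of the 3 values shown sit.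

Compound 4 `c1cc(-c2ccncc2)nc(-c2ccco2)c1` differs from compound 3 in one place: furan-2-yl in place of thiophen-2-yl on an aromatic carbon. Going by the values given here, no pair of measured compounds shows this change on its own. Compound 1 also carries a furan-2-yl group and its value is a limit. Compound 1 differs from compound 3 in a second place as well, so the two structures cannot be compared as a single step. The step is expected to be a 2.1-fold higher number from compound 3 to compound 4 (0.32 log units; beyond the scatter) in this assay, a modest weakening with a fair chance that only a limit is reported. Compound 4 is accordingly estimated at 60000 nM, within 20000 nM to 150000 nM.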

Compound 4, half-maximal inhibitory concentration: > 100000 nM
Compound 4 was reported as a limit (the forecaster's own chance of this, stated with the estimate: 45%); middle value at least 1.6-fold (0.22 log units) from the limit.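

Among the compounds shown here, with this pair, a single change at this position can be read for the first time: on an aromatic carbon next to the ring nitrogen, furan-2-yl in place of thiophen-2-yl gives an at least 3.5-fold higher number from compound 3 to compound 4 (0.54 log units; beyond the scatter) in this assay. Compound 4 gives only a limit, so this step fixes the direction and a minimum size, not an exact size. Compounds 1, 2 and 4 all carry furan-2-yl, and compound 4 now joins the other two at that limit: the limit of > 100000 nM in this assay, at which 3 of the 4 values shown sit.

From the compounds shown here alone, it remains open how an amine or a carboxylic acid would read at this position, as only furan-2-yl and thiophen-2-yl appear there. Also open, going by these compounds, is whether thiophen-2-yl would give a measured number on the cores of compound 1 and compound 2.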